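Three limits and a fourth compound: expecting compound 4

The source may report more compounds than this note shows. Statements on the series, on what has been measured and on what is new or still open speak of the compounds shown alone.

Compound 1 `C/C(=N\C(C)C)c1c(O)c2ccccc2oc1=O` gives >= 100000 nM in an assay on isolated protein for inhibition of myosin-2 (Bos taurus), read by spectrophotometry, with a stated time of 24 min (on this read-out higher numbers stand for weaker inhibition and lower numbers for stronger inhibition), which is a limit of the assay.
Compound 2 `C/C(=N\OCc1ccccc1)c1c(O)c2ccccc2oc1=O` gives >= 100000 nM in this assay, also a limit of the assay.
Compound 3 `CCC/C(=N\Cc1ccccc1)c1c(O)c2ccccc2oc1=O` gives >= 100000 nM in this assay, again a limit of the assay.

Compound 1 therefore stands nowhere in particular among these three: its value is only a limit, and the same holds for the other two, as the evidence the limit of >= 100000 nM in this assay, at which 3 of the 3 values shown sit, shows. For the measured compounds named here, no compound here has been told apart from another, and no step between measured compounds can be computed.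

Compound 4 `C/C(=N\Cc1cccnc1)c1c(O)c2ccccc2oc1=O` differs from compound 1 in one place, ((pyridin-3-yl)methyl in place of isopropyl on a double-bonded nitrogen). The three measured compounds carry different groups on that same double-bonded nitrogen and all sit at the limit, so a change there has not yet moved anything that the assay could record. The expectation is a step from compound 1 to compound 4 of a number no higher from compound 1 to compound 4 (the limit leaves the size open), none beyond the scatter. Compound 4 is estimated at 100000 nM, between 30000 nM and 300000 nM, most likely reported again as a limit.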

Compound 4, half-maximal inhibitory concentration: 17000 nM
Estimate against measurement, compound 4: 5.9-fold (0.77 log units) above; the measured number lies below the stated range.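

The (pyridin-3-yl)methyl group in place of isopropyl on the double-bonded nitrogen gives an at least 5.8-fold lower number from compound 1 to compound 4 (0.76 log units; beyond the scatter) in this assay, so a change at this position can move the read-out after all. Compound 4, at 17000 nM, is a real number, while compound 1 gives >= 100000 nM, which is a limit of the assay, so the step has a minimum size but no known full size. Compound 4 is the only compound here with a measured number, and steps among the others cannot be read: the limit of >= 100000 nM in this assay, at which 3 of the 4 values shown sit.

The compounds shown do not separate the ring nitrogen from the ring itself, and a plain benzyl group on this nitrogen of the core of compound 1 would address that. Nor do they show how a chain ending in an amine or a carboxylic acid would behave at this position.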